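This account rests on a few compounds, and the source may have more. Where it says the series, first, only, none or still open, it means among the compounds named here.

Measured so far in a functional assay on MCF7 cells (Homo sapiens) for cytotoxicity, read by MTT assay, with a stated time of 24 h; a higher number here means a weaker inhibitor, a lower number a stronger inhibitor:

Compound 1, `Cn1c(-c2ccc(NC(=O)CCl)cc2)nc(-c2ccccc2)c1-c1ccccc1`, gives 42.6 ug/mL.
Compound 2, `Cn1c(-c2ccc(NC(=O)CSc3nc4ccccc4s3)cc2)nc(-c2ccccc2)c1-c1ccccc1`, gives 15.8 ug/mL.

Among the measured compounds shown here, compound 2 holds the lowest number of the two in this assay; its nearest neighbour is compound 1, and the single step in the set, a 2.7-fold lower number from compound 1 to compound 2 (0.43 log units; beyond the scatter), separates them. For the measured compounds named here, that step exchanges a small chloro substituent for the whole (1,3-benzothiazol-2-yl)sulfanyl group and is the only guide available.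

Compound 3, `Cc1nnc(SCC(=O)Nc2ccc(-c3nc(-c4ccccc4)c(-c4ccccc4)n3C)cc2)s1`, is not yet measured. It differs from compound 2 by 5-methyl-1,3,4-thiadiazol-2-yl in place of 1,3-benzothiazol-2-yl on a sulfur. Going by the values given here, no measured pair varies the ring attached to this sulfur, so the step from compound 1 to compound 2 bears only indirectly: it shows that adding a heteroaryl-sulfanyl group at this position moved the number downward by a modest amount, but says nothing about swapping one heteroaryl for another.

With a smaller ring entering in place of the bicyclic one, the expectation is a number close to compound 2, perhaps drifting slightly upward, which would be a 1.4-fold higher number from compound 2 to compound 3 (0.14 log units; within the scatter). Compound 3 is therefore estimated at 22 ug/mL, with a range from 9 ug/mL to 50 ug/mL.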

Compound 3, half-maximal inhibitory concentration: 3.2 ug/mL
Beside the measured number, compound 3's estimate is 6.9-fold (0.84 log units) above it; the whole stated range lies above it.
By their numbers in this assay, from the lowest: compound 3; then compound 2; then compound 1.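

In this assay, the ring on the sulfur matters in its own right: a 4.9-fold lower number from compound 2 to compound 3 (0.69 log units; beyond the scatter) comes from exchanging 1,3-benzothiazol-2-yl for 5-methyl-1,3,4-thiadiazol-2-yl, with the rest of the structure unchanged. Among the compounds shown here, the two heteroaryl groups are therefore not interchangeable at this place, and the total change from the chloro compound, a 13-fold lower number from compound 1 to compound 3 (1.12 log units; beyond the scatter), is the only step in the set printed as large. No measured evidence accounts for the difference between the two rings.

The compounds shown do not separate the contribution of the 5-methyl group from that of the 1,3,4-thiadiazole ring, which 1,3,4-thiadiazol-2-yl without the methyl, or with an amino group in its place, would address. They also leave open whether the sulfur and its saturated chain carbon can be changed, for example by an amine in place of the sulfur or a longer chain up to the carbonyl, and whether the lower number for compound 3 reflects anything beyond cytotoxicity in this one cell line.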